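Arylpiperazine exchange on the shared core, cytotoxicity in DU-145

The compounds below may be only part of what the source reports. "The series", "measured", "known", "first", "only" and "open" are said of these compounds alone.

Measured so far:
compound 1 `CCCCCNc1nc(NCc2ccco2)c2cc(F)ccc2n1` gives 83.6% in a functional assay on DU-145 cells (Homo sapiens) for cytotoxicity, read by MTT assay, with a stated time of 2 days, tested at 10 uM; a higher number here means more inhibition at the concentration tested (going by the name of the read-out), a lower number less inhibition
compound 2 `Cc1cccc(N2CCN(CCCNc3nc(NCc4ccco4)c4ccccc4n3)CC2)c1C` gives 91.5% in this assay
compound 3 `CN(C)CCNc1nc(NCc2ccco2)c2ccccc2n1` gives 20% in this assay

Compound 2 holds the highest of the three numbers in this assay. Compound 1 stands within the scatter of it, so no order between these two is claimed; compound 3 lies far below, beyond the scatter. Compound 4 `Clc1cccc(N2CCN(CCCNc3nc(NCc4ccco4)c4ccccc4n3)CC2)c1Cl` is not yet measured and differs from compound 2 in one place: 2,3-dichlorophenyl in place of 2,3-dimethylphenyl on an amine nitrogen in a ring. Going by the values given here, no measured pair shows this exchange, so its size is unknown. A small step downward, or none beyond the scatter, is expected in this assay, giving a number 6.5 percentage points lower from compound 2 to compound 4 (within the scatter). For compound 4 the estimate in this assay is 85%, expected between 65% and 97%.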

Compound 4, a percentage reported as inhibition, at one concentration (the size of the read-out at that concentration, not a potency): 93.2%
The estimate for compound 4 lay 8.2 percentage points below the measured number; low and high end bracket the measured number.
By their numbers in this assay, from the lowest: compound 3; then compounds 1, 2 and 4 (each within the scatter of the next).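

Going by these compounds alone, exchanging 2,3-dimethylphenyl for 2,3-dichlorophenyl is the first single-place step, and in this assay it gives a number 1.7 percentage points higher from compound 2 to compound 4 (within the scatter). On this amine nitrogen in a ring, the two groups therefore cannot be told apart in this read-out, and the high number of compound 2 does not depend on keeping 2,3-dimethylphenyl. Nothing measured on the compounds bears on this result. On these data alone, whether a plain phenyl or a methoxyphenyl on that nitrogen would keep the number stays open, as does the effect of a longer chain carrying the piperazine-type ring.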